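Aryl Substituent Swap on a Shared Core: Compound 3

A few compounds are considered here, and "the series" means these few. Any claim that something is new, unique, unknown or untested is made for them only; others in the source may bear on it.

Compound 1 `CO/C(O)=C1\C(C)=NC(C)=C(C(=O)OCC(C)C)C1c1cccc(OC)c1`: 7.1 nM
Compound 2 `CO/C(O)=C1\C(C)=NC(C)=C(C(=O)OCC(C)C)C1c1cccc(C(F)(F)F)c1`: 15 nM

Of the two numbers in a functional assay (muscle tissue) for inhibition, with Cavia porcellus as the target (on this read-out higher numbers stand for weaker inhibition and lower numbers for stronger inhibition), compound 1 holds the lowest, and compound 2 stands nearest with a 2.1-fold higher number from compound 1 to compound 2 (0.32 log units; beyond the scatter). Compound 3 `CO/C(O)=C1\C(C)=NC(C)=C(C(=O)OCC(C)C)C1c1ccc(Cl)cc1` differs from compound 1 in one place: 4-chlorophenyl in place of 3-methoxyphenyl on a saturated ring carbon. Going by the values given here, only that one step, from a change on the same aryl group, bears on it, and it was modest. A change of the ring substituent and its place is therefore expected to give a modest to moderate rise rather than none. Compound 3 is estimated at 25 nM, within 8 nM to 80 nM, which means an expected 3.5-fold higher number from compound 1 to compound 3 (0.55 log units; beyond the scatter).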

Compound 3, half-maximal inhibitory concentration: 27 nM
The estimate for compound 3 lay 1.1-fold (0.03 log units) below the measured number; the range from low to high includes it.
By their numbers in this assay, from the lowest: compound 1; then compounds 2 and 3 (each within the scatter of the next).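

In this assay, 4-chlorophenyl in place of 3-methoxyphenyl gives a 3.8-fold higher number from compound 1 to compound 3 (0.58 log units; beyond the scatter), a modest step, so this position accepts a change of both the substituent and its place on the aryl group at a modest cost. Compound 2 at 15 nM and compound 3 at 27 nM lie within the scatter of each other, and compound 1 keeps the lowest number of the three. Nothing available explains the step. On these data alone, the substituent and its place changed together, so their separate contributions remain open. As far as these compounds go, how an amine or a carboxylic acid on the aryl group would read also remains open.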